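From 3-methylthiophen-2-yl to 2-methoxyphenyl on a shared core

The source may report more compounds than this note shows. Statements on the series, on what has been measured and on what is new or still open speak of the compounds shown alone.

Compound 1 `CN(C)c1ccc(/C=C(/SCc2ccc(Cl)cc2)C(=O)c2ccc(Br)cc2)cc1`: 10000 nM
Compound 2 `Cc1ccsc1/C=C(/SCc1ccc(Cl)cc1)C(=O)c1ccc(Br)cc1`: 25000 nM

Going by the values given here, in a functional assay on DU-145 cells (Homo sapiens) for inhibition, read by trypan blue exclusion, with a stated time of 96 h (on this read-out higher numbers stand for weaker inhibition of growth and lower numbers for stronger inhibition of growth), compound 2 gives 25000 nM as the higher of the two numbers so far, which makes it the weaker growth inhibitor of the pair. Compound 3 `COc1ccccc1/C=C(/SCc1ccc(Cl)cc1)C(=O)c1ccc(Br)cc1` keeps the shared core with one change: 2-methoxyphenyl in place of 3-methylthiophen-2-yl on a double-bonded chain carbon bound to a double-bonded chain carbon (2-methoxyphenyl in place of 3-methylthiophen-2-yl). Among the compounds with values here, only one measured step bears on this place, and it involves compound 1: a 2.5-fold higher number from compound 1 to compound 2 (0.40 log units; beyond the scatter) is a modest move. Compound 3 carries a phenyl group again, as compound 1 does, so a similarly modest move towards a lower number is expected, though one step is a thin guide. In this assay the expected step is a 1.7-fold lower number from compound 2 to compound 3 (0.22 log units; within the scatter) and may well stay within the scatter. The estimate for compound 3 is 15000 nM with 5000 nM to 40000 nM as its expected range.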

Compound 3, concentration for 50% growth inhibition: 1000 nM
Compound 3: middle estimate off by 15-fold (1.18 log units), on the high side; the measured number lies below the stated range.
By their numbers in this assay, from the lowest: compound 3; then compound 1; then compound 2.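

In this assay, this place on the double-bonded chain carbon turns out to be far more sensitive than the first pair suggested: the swap to 2-methoxyphenyl gives a 25-fold lower number from compound 2 to compound 3 (1.40 log units; beyond the scatter) and so outweighs the earlier step by a wide margin. Carrying a six-membered aromatic ring of carbon only is not enough on its own, as compound 1 and compound 3 both have one and the change between them still gives a 10-fold lower number from compound 1 to compound 3 (1.00 log units; beyond the scatter) in favour of compound 3. Compound 3 is therefore the strongest growth inhibitor of the three.

Still open, going by these compounds, is whether the methoxy group itself matters, which an unsubstituted phenyl group or a 2-hydroxyphenyl group at this place would help to settle. Nothing available here explains the size of these steps.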